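Carrying one fluoro change from a measured pair to an unmeasured one

This account rests on a few compounds, and the source may have more. Where it says the series, first, only, none or still open, it means among the compounds named here.

Compound 1 `N/C(=N\NC(=S)N1CCCCCC1)c1ccccn1` and compound 2 `N/C(=N\NC(=S)N1CCOCC1)c1ccccn1` have different cores, and the difference between the two cores is not broken down here. In a functional assay on A-431 cells (Homo sapiens) for cytotoxicity, read by MTT assay, with a stated time of 72 h, tested at 3 uM (a higher number here means more inhibition of growth at the concentration tested, a lower number less inhibition of growth), compound 1 gives 50.3%, while compound 2 gives 43.1%. Compound 3 `N/C(=N\NC(=S)N1CCOCC1)c1ccc(F)cn1` comes from compound 2 by a single change, (fluoro in place of hydrogen on an aromatic carbon), and in this assay compound 3 gives 47%, which makes the step of a number 3.9 percentage points higher from compound 2 to compound 3 (within the scatter). Compound 4 `N/C(=N\NC(=S)N1CCCCCC1)c1ccc(F)cn1` comes from compound 1 by the same change at the same place, (fluoro in place of hydrogen on an aromatic carbon). Because the step of a number 3.9 percentage points higher from compound 2 to compound 3 (within the scatter) stayed within the scatter, the step expected here, a number 2.7 percentage points higher from compound 1 to compound 4 (within the scatter), is also expected to be small. Compound 4 is therefore estimated at 53% in this assay, with an expected range from 41% to 65%.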

Compound 4, percent growth inhibition at one concentration: 62.4%
Estimate against measurement, compound 4: 9.4 percentage points below; the measured number falls inside the stated range.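

In this assay, fluoro in place of hydrogen on an aromatic carbon gives a number 12.1 percentage points higher from compound 1 to compound 4 (beyond the scatter). Set beside the earlier step, the change cannot be told apart between the two cores: the same change on two cores in this assay, a number 3.9 percentage points higher (within the scatter) from compound 2 to compound 3 and a number 12.1 percentage points higher (beyond the scatter) from compound 1 to compound 4, 8.2 percentage points apart, within the scatter of two such steps. Among the compounds shown here, this shows that the two cores give no detectable difference in this step, but it does not fix one size for the step, as only one of the two steps stands clear of the scatter, and two cores in one assay make no rule for the series.

The compounds shown leave open whether chloro or methoxy at the same place would behave as fluoro does. They also leave open how fluoro would behave on a third core.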